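Ethyl for 4-Fluorophenyl at the Assay Limit

The source may report more compounds than this note shows. Statements on the series, on what has been measured and on what is new or still open speak of the compounds shown alone.

Compound 1 (`CC(C)n1nc(-c2ccon2)c2c(N)ncnc21`) and compound 2 (`CC(C)n1nc(-c2cc(-c3ccc(F)cc3)on2)c2c(N)ncnc21`) share one core. In an ADME assay on BaF3 cells (Mus musculus) for cytotoxicity, read by MTT assay, with a stated time of 48 h (on this read-out lower numbers stand for stronger inhibition of growth and higher numbers for weaker inhibition of growth), compound 1 gives > 10000 nM as a limit of the assay and not a number. Compound 2 gives > 10000 nM as a limit too, so it has no number on this scale. The evidence so far amounts to this (the limit of > 10000 nM in this assay, at which 2 of the 2 values shown sit). Compound 3 (`CCc1cc(-c2nn(C(C)C)c3ncnc(N)c23)no1`) carries ethyl in place of 4-fluorophenyl on an aromatic carbon. Going by the values given here, the one measured step (a step that the two limits leave unreadable from compound 1 to compound 2) offers no size to carry over, so no step beyond the scatter, in either direction, is expected in this assay for this change. Compound 3 is expected to stay at the limit. For compound 3 the estimated value is 12000 nM within an expected range of 5000 nM to 30000 nM in this assay as well. The expected step (a step that the limit leaves unreadable from compound 2 to compound 3) remains an estimate.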

Compound 3, concentration for 50% growth inhibition: > 10000 nM
Compound 3 gave a limit, no number; the forecaster's own chance of this, stated with the estimate: 85%; the middle value is on the limit's open side.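

Going by these compounds alone, compound 1, compound 2 and compound 3 all sit at a limit and not at a number, so no step among them can be read. They leave open whether any group on this aromatic carbon would give the shared core a measurable growth inhibition: the limit of > 10000 nM in this assay, at which 3 of the 3 values shown sit.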